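The compounds below may be only part of what the source reports. "The series", "measured", "known", "first", "only" and "open" are said of these compounds alone.

Measured compounds:
compound 1 `O=C1CC(c2ccccc2)n2ncnc2N1` gives 51.9 mg/kg
compound 2 `O=C1CC(c2cccc(Cl)c2)n2ncnc2N1` gives 47.3 mg/kg
compound 3 `O=C1CC(c2ccccc2Br)n2ncnc2N1` gives 19.7 mg/kg

In a functional assay on the whole organism (strain Kunming) with Mus musculus as the target (a lower number here means that less compound is needed, a higher number that more compound is needed for the effect), compound 2 stands second highest of the three numbers, within the scatter of compound 1 and separated from compound 3 by a step beyond the scatter. Compound 4 `O=C1CC(c2cccc(C(F)(F)F)c2)n2ncnc2N1` differs from compound 2 by trifluoromethyl in place of chloro on an aromatic carbon. Among the compounds with values here, no measured step exchanges one halogen-type group for another; the nearest are a 1.1-fold lower number from compound 1 to compound 2 (0.04 log units; within the scatter), which shows chloro entering at this position without effect beyond the scatter, and a 2.6-fold lower number from compound 1 to compound 3 (0.42 log units; beyond the scatter), a modest step for bromo at another position. Neither speaks for a shift from the trifluoromethyl change, so no step beyond the scatter is expected in this assay. Compound 4 is therefore estimated at 45 mg/kg, range 22 mg/kg to 90 mg/kg, an expected step of a 1.1-fold lower number from compound 2 to compound 4 (0.02 log units; within the scatter).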

Compound 4, dose for half-maximal effect: 54.8 mg/kg
The estimate for compound 4 lay 1.2-fold (0.09 log units) below the measured number; measured number inside the range.
By their numbers in this assay, from the lowest: compound 3; then compounds 2, 1 and 4 (each within the scatter of the next).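

In this assay, trifluoromethyl on an aromatic carbon meta to a large group behaves as chloro does there, with a 1.2-fold higher number from compound 2 to compound 4 (0.06 log units; within the scatter) and a 1.1-fold higher number from compound 1 to compound 4 (0.02 log units; within the scatter). Hydrogen, chloro and trifluoromethyl at this place thus give numbers within the scatter, even though trifluoromethyl carries more heavy atoms than chloro. No evidence on the reason is at hand.

Open, as far as these compounds go, is whether an amine or a carboxylic acid at this place would move the number beyond the scatter. Also open, from the compounds shown here alone, is how trifluoromethyl would behave at the place bromo holds in compound 3.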